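Toward a Methoxyphenyl Amide After Three Untoxic Analogues

The source may report more compounds than this note shows. Statements on the series, on what has been measured and on what is new or still open speak of the compounds shown alone.

Compound 3 `COc1ccc(-c2cnc(NC(=O)c3cccc(C#N)c3)n2C)cc1` is one of three compounds sharing a core whose tolerability by THP-1 cells has been examined in a toxicity assay on THP-1 cells (Homo sapiens) for inhibition; a lower number here means that less compound is tolerated, a higher number that more compound is tolerated. In this assay compound 3 reaches only a limit, > 100000 nM. Compound 1 `COc1ccc(-c2cnc(NC(=O)c3cccc([N+](=O)[O-])c3)n2C)cc1` likewise gives in this assay the limit > 100000 nM. Compound 2 `Cn1cc(-c2ccccc2)nc1NC(=O)c1ccc(F)cc1` gives in this assay the limit > 50000 nM. Every value in hand is therefore a limit rather than a number, summarised by the limit of > 100000 nM in this assay, at which 2 of the 3 values shown sit, and by the limit of > 50000 nM in this assay, at which 1 of the 3 values shown sits. Going by the values given here, the single step between two compounds that differ in one place, a step that the two limits leave unreadable from compound 1 to compound 3, is left unreadable by the two limits, so nothing can be said of its size.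

Compound 4 `COc1ccc(C(=O)Nc2ncc(-c3ccc(OC)cc3)n2C)cc1` differs from compound 3 by 4-methoxyphenyl in place of 3-cyanophenyl on a carbonyl carbon. Among the compounds with values here, no measured step bears directly on this exchange, and the one recorded step gives no size to lean on. The expectation must rest on the fact that all three neighbours sit at limits in this assay. Compound 4 is therefore expected to be tolerated to a similar degree, with an estimated value of 150000 nM lying between 50000 nM and 400000 nM. The estimated step that the limit leaves unreadable from compound 3 to compound 4 is expected to amount to nothing beyond the scatter.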

Compound 4, half-maximal cytotoxic concentration: > 100000 nM
Compound 4 ended at the assay's limit; the forecaster's own chance of this, stated with the estimate: 80%; the middle value is on the limit's open side.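

In this assay compound 4 gives > 100000 nM, which is a limit. Going by these compounds alone, compound 3 also stands at a limit, so no step between compound 3 and compound 4 can be read. The compounds shown leave open at what concentration, if any, each becomes toxic to these cells, and whether any exchange on the shared core alters tolerance.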